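Amino for methyl on the thiadiazole: inactive chromone pair

This account rests on a few compounds, and the source may have more. Where it says the series, first, only, none or still open, it means among the compounds named here.

Measured so far:
Compound 1 `Nc1nnc(SCc2cc(=O)c3cc(Cl)ccc3o2)s1`: in a functional assay on LM7 cells (Homo sapiens) for cytotoxicity, read by MTT assay, with a stated time of 72 h (on this read-out higher numbers stand for weaker inhibition and lower numbers for stronger inhibition), compound 1 gives > 25000 nM, a limit of the assay, not a number.
Compound 2 `Cc1ccc2oc(CSc3nnc(C)s3)cc(=O)c2c1`: in this assay compound 2 gives > 25000 nM, again only a limit.

Both values sit at the same limit (the limit of > 25000 nM in this assay, at which 2 of the 2 values shown sit), so compound 2 stands nowhere distinguishable from compound 1. Compound 3 `Cc1ccc2oc(CSc3nnc(N)s3)cc(=O)c2c1` differs from compound 2 by amino in place of methyl on an aromatic carbon. For the measured compounds named here, no measured step covers this change. Compound 1 carries the same amino group and in this assay gives only the limit > 25000 nM. No step beyond the scatter is therefore expected, in either direction. The expected step is a number no higher from compound 2 to compound 3 (the limit leaves the size open). Compound 3 is estimated at 25000 nM, with a range from 10000 nM to 60000 nM.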

Compound 3, half-maximal inhibitory concentration: > 25000 nM
Compound 3: a limit, no number (the forecaster's own chance of this, stated with the estimate: 85%); the middle value sits exactly at the limit.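

No step can be read from compound 2 or compound 1 to compound 3, since all three values are limits: the limit of > 25000 nM in this assay, at which 3 of the 3 values shown sit.

The compounds shown leave open whether amino in place of methyl, or methyl in place of chloro, changes cytotoxicity at all.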